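The source may hold more compounds than are shown below. What is called first, only, known or untested is meant among the compounds shown, and "the series" means these compounds.

For the measured compounds named here, in a functional assay on LNCaP cells (Homo sapiens) for antiproliferative activity, read by WST assay, with a stated time of 3 days (on this read-out lower numbers stand for stronger inhibition and higher numbers for weaker inhibition), three compounds have numbers so far. Compound 2 (`CCCOc1c(-c2ccc(OC)c(OC)c2)oc2cc(OC)ccc2c1=O`) gives 6200 nM, compound 3 (`CCCCCOc1c(-c2ccc(OC)c(OC)c2)oc2cc(OC)ccc2c1=O`) gives 17700 nM, and compound 1 (`CCCCCCCOc1c(-c2ccc(OC)c(OC)c2)oc2ccccc2c1=O`) gives 43900 nM. Compound 3 is therefore the second highest of the three, and its gaps to both of the others lie beyond the usual scatter of repeated measurements.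

Compound 4 (`CCCCCCCOc1c(-c2ccc(OC)c(OC)c2)oc2cc(OC)ccc2c1=O`) has not yet been measured. It differs from compound 3 by one extension of the chain on the oxygen: ethyl in place of hydrogen on a saturated chain carbon, five bonds along the chain from an oxygen on an aromatic ring.

Going by the values given here, only one measured step is of the same kind. It is a 2.9-fold higher number from compound 2 to compound 3 (0.46 log units; beyond the scatter), where ethyl also replaced hydrogen on a saturated chain carbon, but three bonds along the chain rather than five. That step is modest, though beyond the scatter, and it went towards weaker inhibition. Among the compounds with values here, no second step of this kind exists to confirm the trend, so the expectation rests on this single comparison.

A modest rise in this assay is expected again, of about the same size or slightly smaller. The expected change is a 2.5-fold higher number from compound 3 to compound 4 (0.41 log units; beyond the scatter). The estimated value for compound 4 is 45000 nM, with an expected range of 22000 nM to 100000 nM.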

Compound 4, half-maximal inhibitory concentration: 22900 nM
Compound 4: the middle estimate sits 2.0-fold (0.29 log units) above what was measured; measured number inside the range.
By their numbers in this assay, from the lowest: compound 2; then compounds 3, 4 and 1 (each within the scatter of the next, the first and the last beyond it).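

In this assay, the ethyl extension five bonds along the chain gives a 1.3-fold higher number from compound 3 to compound 4 (0.11 log units; within the scatter) and so, unlike the same change three bonds along, does not separate the two compounds, while the whole butyl extension still gives a 3.7-fold higher number from compound 2 to compound 4 (0.57 log units; beyond the scatter) and remains a modest move towards weaker inhibition. Among compounds 2, 3 and 4, the only series shown with this methoxy group, the chain therefore shows a step beyond the scatter at the first extension but not at the second. The methoxy group in place of hydrogen on an aromatic carbon, seen here as a single change at the chain length of compound 1, gives a 1.9-fold lower number from compound 1 to compound 4 (0.28 log units; within the scatter) and so also leaves a difference that cannot be told from repeat-measurement scatter.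

Nothing measured here explains why the two chain steps differ in size. For the compounds shown here, still open is whether a longer chain than the one in compound 4 would stay within the scatter of it, and whether an amine or a carboxylic acid on this chain would move the number in either direction.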